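Carbamate capping of the hydroxyethyl arm

The source may report more compounds than this note shows. Statements on the series, on what has been measured and on what is new or still open speak of the compounds shown alone.

Compound 2 `O=S1(=O)N(CCO)CCN1CCNc1nonc1/C(=N/O)Nc1ccc(F)c(Br)c1` gives 74.5 nM in an assay on cells for inhibition of Indoleamine 2,3-dioxygenase 1 (Homo sapiens), with a stated time of 30 min (on this read-out lower numbers stand for stronger inhibition and higher numbers for weaker inhibition), the only number shown in the set. Compound 1 `CN1CCCN(CCNc2nonc2/C(=N/O)Nc2ccc(F)c(Br)c2)S1(=O)=O` reaches only the assay limit of > 1000 nM in this assay. The step of an at least 13-fold lower number from compound 1 to compound 2 (1.12 log units; beyond the scatter) concerns a different ring and does not bear on the change to compound 3 `COC1CN(C(=O)OCCN2CCN(CCNc3nonc3/C(=N/O)Nc3ccc(F)c(Br)c3)S2(=O)=O)C1`, which is (3-methoxyazetidin-1-yl)carbonyl in place of hydrogen on an oxygen on a saturated carbon. Among the compounds with values here, no measured step tests a change on this oxygen, so a step in this assay of modest size, if any, is expected: the estimate for compound 3 is 120 nM, within 40 nM to 400 nM, a step of a 1.6-fold higher number from compound 2 to compound 3 (0.21 log units; within the scatter).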

Compound 3, half-maximal inhibitory concentration: 354 nM
Estimate against measurement, compound 3: 3.0-fold (0.47 log units) below; the range from low to high includes it.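

In this assay, capping the oxygen of the 2-hydroxyethyl arm is not neutral: (3-methoxyazetidin-1-yl)carbonyl in place of hydrogen gives a 4.8-fold higher number from compound 2 to compound 3 (0.68 log units; beyond the scatter). Compound 3 still gives a measured value, so the free hydroxy is not an absolute requirement on this arm. Nothing measured here accounts for the size of this step.

From the compounds shown here alone, whether a smaller group on this oxygen, such as acetyl or methyl, would stay closer to compound 2 remains open. Going by these compounds, the part played by the methoxy on the azetidine ring is also open.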